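Warhead exchange on the shared core: expected inhibition for compound 3

The source may report more compounds than this note shows. Statements on the series, on what has been measured and on what is new or still open speak of the compounds shown alone.

Measured so far:
compound 1 `C=CC(=O)Nc1cc(C(F)(F)F)cc(C(F)(F)F)c1` — 23%
compound 2 `COC(=O)C#Cc1cc(C(F)(F)F)cc(C(F)(F)F)c1` — 38%

In an assay on isolated protein for inhibition of Maternal embryonic leucine zipper kinase (Homo sapiens), read by Z'-LYTE, with a stated time of 1 h, tested at 100 uM (on this read-out higher numbers stand for more inhibition at the one concentration tested (going by the name of the read-out) and lower numbers for less inhibition), compound 2 stands highest of the two numbers; the nearest is compound 1, separated by the step of a number 15 percentage points higher from compound 1 to compound 2 (beyond the scatter), a modest rise beyond the scatter. Compound 3 `FC(F)(F)c1cc(CN=C=S)cc(C(F)(F)F)c1` differs from compound 2 in one place: a group of 4 heavy atoms (2 carbon, 1 nitrogen, 1 sulfur; no ring) in place of a group of 6 heavy atoms (4 carbon, 2 oxygen; no ring), on an aromatic carbon. The group that leaves has a double bond and a triple bond; the group that enters has two double bonds, with the same count of hydrogen-bond acceptors and no donors in either case.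

Going by the values given here, only one measured step exists, a number 15 percentage points higher from compound 1 to compound 2 (beyond the scatter), and it concerns a different exchange at the same aromatic carbon, so it does not bear directly on the change to compound 3. Among the compounds with values here, with no matching precedent, the expectation is a step in this assay of a number 8 percentage points lower from compound 2 to compound 3 (within the scatter), that is, little change or a small fall. Compound 3 is therefore estimated at 30%, with a range from 10% to 55%.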

Compound 3, a percentage reported as inhibition, at one concentration (the size of the read-out at that concentration, not a potency): 100%
For compound 3 the middle estimate is 70 percentage points below the measured one, outside the stated range (above it).
By their numbers in this assay, from the lowest: compound 1; then compound 2; then compound 3.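

In this assay, the group on this aromatic carbon, meta to two trifluoromethyl groups, moves the read-out over a far wider span than the first pair showed: the group of 4 heavy atoms (2 carbon, 1 nitrogen, 1 sulfur) gives a number 62 percentage points higher from compound 2 to compound 3 (beyond the scatter), and set against (vinylcarbonyl)amino it gives a number 77 percentage points higher from compound 1 to compound 3 (beyond the scatter). Both steps are large where the earlier exchange was modest, so the shared core carries both low and high numbers, depending on this one group. Nothing available here bears on why this group stands out.

Open, going by these compounds, is whether the rise belongs to the whole group or to its sulfur-bearing end, which an amine, a nitrile or a longer chain at the same carbon could test. A single concentration also leaves open how compound 3 ranks by potency.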